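Trimming a Methyl from the Sulfonyl Thiazole

The compounds below may be only part of what the source reports. "The series", "measured", "known", "first", "only" and "open" are said of these compounds alone.

Of the compounds shown here, three sharing one core have been measured in a functional assay on CHO-K1 cells for antagonist activity at prostaglandin E2 receptor EP3 subtype (Homo sapiens), read by TR-FRET and cAMP accumulation, with a stated time of 30 min; on this read-out lower numbers stand for stronger inhibition and higher numbers for weaker inhibition. Compound 1 `O=C(NS(=O)(=O)c1cc(Cl)c(Cl)s1)OC/C=C1\CCCc2cnn(Cc3ccc(Cl)cc3Cl)c21` gives 5 nM, compound 2 `O=C(NC/C=C1\CCCc2cnn(Cc3ccc(Cl)cc3Cl)c21)NS(=O)(=O)c1ccc(Cl)cc1` gives 12 nM, and compound 3 `Cc1nc(C)c(S(=O)(=O)NC(=O)NC/C=C2\CCCc3cnn(Cc4ccc(Cl)cc4Cl)c32)s1` gives 4 nM. Among the compounds with values here, the only single-point step is a 3.0-fold lower number from compound 2 to compound 3 (0.48 log units; beyond the scatter). Compound 3 thus has the lowest number, though its gap to compound 1 lies within the scatter, so the two cannot be ordered.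

Compound 4 `Cc1ncc(S(=O)(=O)NC(=O)NC/C=C2\CCCc3cnn(Cc4ccc(Cl)cc4Cl)c32)s1` differs from compound 3 by hydrogen in place of methyl on an aromatic carbon. Within the data shown here, no measured step removes a methyl from this ring; the one step touching the ring, a 3.0-fold lower number from compound 2 to compound 3 (0.48 log units; beyond the scatter), swapped the whole group and was modest. A small change is therefore expected, likely a slightly higher number: a 1.8-fold higher number from compound 3 to compound 4 (0.24 log units; within the scatter). Compound 4 is estimated at 7 nM, between 2.5 nM and 20 nM.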

Compound 4, half-maximal inhibitory concentration: 9 nM
The estimate for compound 4 lay 1.3-fold (0.11 log units) below the measured number; the range from low to high includes it.
By their numbers in this assay, from the lowest: compounds 3, 1, 4 and 2 (each within the scatter of the next, the first and the last beyond it).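

In this assay, the methyl next to the ring nitrogen matters on its own: its loss gives a 2.3-fold higher number from compound 3 to compound 4 (0.35 log units; beyond the scatter) and this modest step lies beyond the scatter. Without it, the thiazole group no longer stands clearly apart from 4-chlorophenyl, with a 1.3-fold lower number from compound 2 to compound 4 (0.12 log units; within the scatter) lying within the scatter. Nothing measured here accounts for this effect.

Open, from the compounds shown here alone, is how an ethyl group, a chlorine or an amine on this same ring carbon would compare with methyl. Also open, going by these compounds, is what the remaining methyl contributes.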